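The source may hold more compounds than are shown below. What is called first, only, known or untested is meant among the compounds shown, and "the series" means these compounds.

In a functional assay on PANC-1 cells (Homo sapiens) for inhibition, read by MTT assay, with a stated time of 24 h, tested at 10 uM (on this read-out lower numbers stand for less inhibition and higher numbers for more inhibition at the one concentration tested (going by the name of the read-out)), compound 2 `CC(C)=CCOc1cc(=O)n(CCCO)c2c1CC(CC=C(C)C)C(C)(C)C2` gives 7.5%. Compound 1 `CC(C)=CCC/C(C)=C/CC1Cc2c(O)cc(=O)n(CCCO)c2CC1(C)C` gives 0% and compound 3 `COc1ccc(C(=O)NCCCOc2cc(=O)n(CCCO)c3c2CC(CC=C(C)C)C(C)(C)C3)cc1` gives 2.5% in this assay; these readings differ from that of compound 2 by less than the usual scatter, so the three compounds cannot be told apart, and all three show little inhibition at the tested concentration. Compound 4 `CC(C)=CCC1Cc2c(OC(=O)Nc3ccc(Cl)c(Cl)c3)cc(=O)n(CCCO)c2CC1(C)C` has not yet been measured. It differs from compound 2 in one place: (3,4-dichlorophenyl)carbamoyl in place of 3-methylbut-2-en-1-yl on an oxygen on an aromatic ring. For the measured compounds named here, no measured pair shows a change of this kind, so the expected step from compound 2 to compound 4 is a number 7.5 percentage points higher from compound 2 to compound 4 (within the scatter), a slight rise that may still fall within the scatter. Compound 4 is expected to give about 15% in this assay, with a likely range from 0% to 45%.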

Compound 4, a percentage reported as inhibition, at one concentration (the size of the read-out at that concentration, not a potency): 1.8%
Beside the measured number, compound 4's estimate is 13.2 percentage points above it, and the stated range covers the measured number.
By their numbers in this assay, from the lowest: compounds 1, 4, 3 and 2 (each within the scatter of the next).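

Putting (3,4-dichlorophenyl)carbamoyl in place of 3-methylbut-2-en-1-yl on an oxygen on an aromatic ring gives a number 5.7 percentage points lower from compound 2 to compound 4 (within the scatter) in this assay. This position therefore takes a larger group, with an aromatic ring and a hydrogen-bond donor, without a change that can be told from scatter, and inhibition stays slight. No measurement here offers an explanation for this result.

From the compounds shown here alone, whether a carboxylic acid or an amine on this oxygen would raise inhibition in this assay stays open. So does whether any group at this position can do so.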